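The compounds below may be only part of what the source reports. "The series", "measured", "known", "first", "only" and "open" are said of these compounds alone.

Working notes on the series.

Compound 1 `C#CCN(C)CCCCCOc1ccc2c(c1)CCC2=O` and compound 2 `C#CCN(C)CCCCCCOc1ccc2c(c1)CCC2=O` share a core and differ in their chains. In an assay on BTI cells for inhibition of Amine oxidase [flavin-containing] B (Homo sapiens), read by fluorescence and Amplex Red, with a stated time of 15 min (a higher number here means a weaker inhibitor, a lower number a stronger inhibitor), compound 1 gives 94.8 nM, and compound 2 gives 129 nM. The change between them is (methyl(propargyl)amino)methyl in place of methyl(propargyl)amino on a saturated chain carbon, five bonds along the chain from an oxygen on an aromatic ring, and the step it made was a 1.4-fold higher number from compound 1 to compound 2 (0.13 log units; within the scatter), so the two values cannot be told apart here.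

Compound 3 `C#CCN(C)CCCOc1ccc2c(c1)OCCC2=O` carries a different core; how the core of compound 3 differs from that of compound 1 is not broken down here. In this assay compound 3 gives 11400 nM, the highest of the three numbers, and its distance from compound 1 and from compound 2 lies beyond the scatter.

Compound 4 `C#CCN(C)CCCCOc1ccc2c(c1)OCCC2=O` has not yet been measured. It differs from compound 3 by (methyl(propargyl)amino)methyl in place of methyl(propargyl)amino on a saturated chain carbon, three bonds along the chain from an oxygen on an aromatic ring. This is the same kind of change as that from compound 1 to compound 2, but the place is not the same: there the change sat five bonds along the chain from an oxygen on an aromatic ring, here it sits three bonds along the chain from an oxygen on an aromatic ring. For the measured compounds named here, the one measured case of this kind of change, compound 1 to compound 2, gave a 1.4-fold higher number from compound 1 to compound 2 (0.13 log units; within the scatter), and this is the only guide. For compound 4 in this assay a step of about a 1.3-fold lower number from compound 3 to compound 4 (0.10 log units; within the scatter) is expected, with the difference in place as the main uncertainty. The estimate for compound 4 in this assay is 9000 nM, expected to fall between 2500 nM and 30000 nM.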

Compound 4, half-maximal inhibitory concentration: 58.9 nM
The estimate for compound 4 lay 150-fold (2.18 log units) above the measured number; measured number outside the range, below it.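

In this assay, (methyl(propargyl)amino)methyl in place of methyl(propargyl)amino gave a 190-fold lower number from compound 3 to compound 4 (2.29 log units; beyond the scatter), a large step on the core of compound 3. Set beside the earlier step, the same change did not carry over from one core to the other in this assay: the same change on two cores in this assay, a 1.4-fold higher number (0.13 log units; within the scatter) from compound 1 to compound 2 and a 190-fold lower number (2.29 log units; beyond the scatter) from compound 3 to compound 4, 260-fold (2.42 log units) apart, beyond the scatter of two such steps. This shows that the size of the step on one core was no guide to its size on the other in this series, but it does not show what sets the two apart, as the pairs differ both in core and in place, with the change sitting three bonds along the chain from an oxygen on an aromatic ring in one pair and five bonds along in the other.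

The compounds shown leave open whether the large step belongs to the core of compound 3 or to the place of the change, a question that the same change at three bonds along the chain on the core of compound 1 would address. Also open, on these data alone, is whether a longer chain on the core of compound 3, such as one ending in 2-(methyl(propargyl)amino)ethyl, would stay close to compound 4 at 58.9 nM or move away from it.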